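Swapping a Methyl Group for Hydrogen on Compound 2

The source may report more compounds than this note shows. Statements on the series, on what has been measured and on what is new or still open speak of the compounds shown alone.

- compound 1 `[O-][n+]1nc(NC2CCCCC2)[n+]([O-])c2ccccc21` gives 9500 nM 
- compound 2 `Cc1ccc(Nc2n[n+]([O-])c3ccccc3[n+]2[O-])cc1` gives 10600 nM 

In a functional assay on HepG2 cells (Homo sapiens) for cytotoxicity, read by MTT assay, with a stated time of 48 h (on this read-out higher numbers stand for weaker inhibition and lower numbers for stronger inhibition), compound 2 (10600 nM) lies within the usual scatter of compound 1 (9500 nM), so these two numbers cannot be told apart. Compound 3 `[O-][n+]1nc(Nc2ccccc2)[n+]([O-])c2ccccc21` has hydrogen in place of methyl on an aromatic carbon, para to a large group (hydrogen in place of methyl on an aromatic carbon). Among the measured compounds shown here, no measured pair shows this change, so the expectation rests on these two values alone. The expected change is small, with a 1.1-fold lower number from compound 2 to compound 3 (0.03 log units; within the scatter) estimated to stay within the scatter, in no clear direction. The estimated value for compound 3 is 10000 nM (range 5000 nM to 20000 nM).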

Compound 3, half-maximal inhibitory concentration: 15000 nM
Compound 3: the middle estimate sits 1.5-fold (0.18 log units) below what was measured; the measured number falls inside the stated range.
By their numbers in this assay, from the lowest: compounds 1, 2 and 3 (each within the scatter of the next).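

In this assay hydrogen in place of methyl on an aromatic carbon, para to a large group, gives a 1.4-fold higher number from compound 2 to compound 3 (0.15 log units; within the scatter) and so makes no difference that can be told apart at this position. Phenyl in place of cyclohexyl on a nitrogen on an aromatic ring gives a 1.6-fold higher number from compound 1 to compound 3 (0.20 log units; within the scatter) and likewise cannot be told apart. No supporting data bear on these results. From the compounds shown here alone, whether an amine, a carboxylic acid or a longer chain at this position would move the number beyond the scatter remains open.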